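From bromo to methoxy on an aromatic ring

The compounds below may be only part of what the source reports. "The series", "measured", "known", "first", "only" and "open" are said of these compounds alone.

Measured so far in a functional assay on K-562R cells (Homo sapiens) for cytotoxicity, read by MTT assay, with a stated time of 48 h (on this read-out higher numbers stand for weaker inhibition and lower numbers for stronger inhibition), are three compounds
- compound 1 `COc1ccc(-c2cn(C(=O)Nc3cc(OC)c(OC)c(OC)c3)c(=O)n2-c2cc(OC)c(OC)c(OC)c2)cc1OC` gives > 50000 nM (a limit of the assay, not a number)
- compound 2 `COc1cc(-n2c(-c3ccccc3)cn(C(C)=O)c2=O)cc(OC)c1OC` gives 9600 nM
- compound 3 `COc1cc(-n2c(-c3ccc(Br)cc3)cn(C(C)=O)c2=O)cc(OC)c1OC` gives 900 nM

Compound 3 has the lowest number shown, and lower numbers mean stronger inhibition. Compound 1 gives only a limit and differs from compound 3 in several places, so it offers no clean comparison.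

The next structure is compound 4 `COc1ccc(-c2cn(C(C)=O)c(=O)n2-c2cc(OC)c(OC)c(OC)c2)cc1`, with methoxy in place of bromo on an aromatic carbon. Among the compounds with values here, one measured step bears on this place: an 11-fold lower number from compound 2 to compound 3 (1.03 log units; beyond the scatter), where bromo replaced hydrogen. Within the data shown here, that large step shows the group here can matter, but no clean step tests methoxy itself. A swap of one group for another is therefore expected to move the number less, with no shift beyond the scatter expected and real uncertainty in both directions. The estimated change is no change at the digits printed from compound 3 to compound 4 (within the scatter) in this assay. For compound 4 the estimated value is 900 nM, with an expected range from 120 nM to 6000 nM.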

Compound 4, half-maximal inhibitory concentration: 9500 nM
Compound 4: the middle estimate sits 11-fold (1.02 log units) below what was measured, outside the stated range (above it).
By their numbers in this assay, from the lowest: compound 3; then compounds 4 and 2 (each within the scatter of the next). At a limit, above all of these: compound 1.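

In this assay there is an 11-fold higher number from compound 3 to compound 4 (1.02 log units; beyond the scatter) when methoxy takes the place of bromo, and there is a 1.0-fold lower number from compound 2 to compound 4 (0.00 log units; within the scatter) when methoxy takes the place of hydrogen on the same aromatic carbon. The earlier gain from hydrogen to bromo therefore does not extend to every group placed here: on these values, methoxy and hydrogen cannot be told apart, and of the three groups shown only bromo stands out. Nothing shown here accounts for this difference between bromo and methoxy.

On these data alone, only hydrogen, bromo and methoxy appear at this place on the otherwise shared core, so it remains open whether bromo is a lone case or one of several groups that give lower numbers. Chloro, an amine or a carboxylic acid on this aromatic carbon would test that question directly.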